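The source may hold more compounds than are shown below. What is called first, only, known or untested is meant among the compounds shown, and "the series" means these compounds.

Measured in a functional assay on P388 cells (Mus musculus) for inhibition; on this read-out higher numbers stand for weaker inhibition and lower numbers for stronger inhibition:
compound 1 `O=C1/C(=C/c2ccccc2)CCc2ccccc21`: 30200 nM
compound 2 `O=C1/C(=C/c2ccc(Br)cc2)CCc2ccccc21`: 20400 nM

Compound 2 holds the lowest of the two numbers in this assay; its nearest neighbour is compound 1, and the step of a 1.5-fold lower number from compound 1 to compound 2 (0.17 log units; within the scatter) is within the scatter, so the two compounds cannot be ordered against each other on these data.

Compound 3 `Cc1ccc(/C=C2\CCc3ccccc3C2=O)cc1` is not yet measured. It differs from compound 2 as follows: methyl in place of bromo on an aromatic carbon. Among the compounds with values here, no measured step exchanges bromo for methyl, so the only bearing step is a 1.5-fold lower number from compound 1 to compound 2 (0.17 log units; within the scatter), which placed bromo on the same aromatic carbon and gave no change beyond the scatter. A single small group on that carbon has so far left the number where it was, and nothing measured suggests that methyl in place of bromo will do otherwise; no step beyond the scatter is therefore expected in this assay for compound 3, with the expected step of a 1.1-fold higher number from compound 2 to compound 3 (0.03 log units; within the scatter) reflecting that.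

The estimate for compound 3 in this assay is 22000 nM, with a range from 9000 nM to 55000 nM.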

Compound 3, half-maximal inhibitory concentration: 17700 nM
Beside the measured number, compound 3's estimate is 1.2-fold (0.09 log units) above it; the measured number falls inside the stated range.
By their numbers in this assay, from the lowest: compounds 3, 2 and 1 (each within the scatter of the next).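

In this assay, within the data shown here, exchanging bromo for methyl on this aromatic carbon gives a 1.2-fold lower number from compound 2 to compound 3 (0.06 log units; within the scatter), so these two groups cannot be told apart at this place, and the earlier compounds offered no such comparison between two groups. Methyl in place of hydrogen gives a 1.7-fold lower number from compound 1 to compound 3 (0.23 log units; within the scatter), so a second group, this time not a halogen, also stays within the scatter of the parent compound, and hydrogen, bromo and methyl on this carbon form a single level with no compound among the three going against it. Nothing available gives a reason for this flat picture or links it to any property of the groups.

Going by these compounds, the three compounds cover only hydrogen and two small groups on one carbon, so it remains open whether an amine, a carboxylic acid, a methoxy group or a longer chain there would move the number beyond the scatter. On these data alone, it also remains open whether methyl or bromo on another carbon of this ring, or a change in the rest of the shared core, would have any greater effect in this assay.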